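Swapping azido for acetamido: cytotoxicity expectations

The compounds below may be only part of what the source reports. "The series", "measured", "known", "first", "only" and "open" are said of these compounds alone.

Measured so far:
compound 1 `C=CCOC[C@H]1[C@@H](COC)C[C@@](CC(C)C)(C(=O)O)N1C(=O)c1ccc(C(C)(C)C)c(OC)c1` — a limit, > 120000 nM
compound 2 `COC[C@H]1C[C@@](CC(C)C)(C(=O)O)N(C(=O)c2ccc(C(C)(C)C)c(OC)c2)[C@H]1CN=[N+]=[N-]` — a limit, > 120000 nM

In an ADME assay on Huh-5-2 cells (Homo sapiens) for cytotoxicity, with a stated time of 3 days (on this read-out lower numbers stand for higher toxicity in this test and higher numbers for lower toxicity in this test), compound 1 reaches only a limit, > 120000 nM. Compound 2 likewise reaches only a limit, > 120000 nM. The step that the two limits leave unreadable from compound 1 to compound 2 therefore cannot be read; both values sit at the limit of > 120000 nM in this assay, at which 2 of the 2 values shown sit. Compound 3 `COC[C@H]1C[C@@](CC(C)C)(C(=O)O)N(C(=O)c2ccc(C(C)(C)C)c(OC)c2)[C@H]1CNC(C)=O` differs from compound 2 by acetamido in place of azido on a saturated chain carbon bound to a saturated ring carbon. Within the data shown here, no measured step gives a readable size, so nothing points to a direction beyond the limit of this assay. Compound 3 is expected to remain at that limit, estimated at 150000 nM (range 60000 nM to 400000 nM), an expected step that the limit leaves unreadable from compound 2 to compound 3 that stays unreadable.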

Compound 3, half-maximal cytotoxic concentration: > 120000 nM
Compound 3 gave a limit, no number; the forecaster's own chance of this, stated with the estimate: 85%; the middle value lies beyond the limit too.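

Compound 3, like compound 1 and compound 2, gives only a limit, so neither new step, from compound 2 or from compound 1 to compound 3, can be read: the limit of > 120000 nM in this assay, at which 3 of the 3 values shown sit.

The compounds shown leave open whether allyloxy, azido and acetamido differ at all in cytotoxicity, with no number for any of them.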